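Piperazin-1-yl Takes the Place of a Ring-Free Group

The compounds below may be only part of what the source reports. "The series", "measured", "known", "first", "only" and "open" are said of these compounds alone.

In a functional assay on SF-268 cells (Homo sapiens) for cytotoxicity, read by MTT assay, with a stated time of 3 days (on this read-out lower numbers stand for stronger inhibition and higher numbers for weaker inhibition), compound 1 `CNc1nc(SCc2nc3ccccc3[nH]2)nc(-c2ccccc2)c1C#N` gives 3.2 nM, compound 2 `N#Cc1c(Nc2nccs2)nc(SCc2nc3ccccc3[nH]2)nc1-c1ccccc1` gives 2.55 nM and compound 3 `N#Cc1c(NC(N)=S)nc(SCc2nc3ccccc3[nH]2)nc1-c1ccccc1` gives 3.37 nM, so compound 3 stands within the scatter of both others. Compound 4 `N#Cc1c(-c2ccccc2)nc(SCc2nc3ccccc3[nH]2)nc1N1CCNCC1` differs from compound 3 on an aromatic carbon ortho to a cyano group: a group of 6 heavy atoms (4 carbon, 2 nitrogen; one six-membered non-aromatic ring with 2 hetero atoms) in place of a group of 4 heavy atoms (1 carbon, 2 nitrogen, 1 sulfur; no ring), on an aromatic carbon. Going by the values given here, three measured steps bear on this place: a 1.3-fold lower number from compound 1 to compound 2 (0.10 log units; within the scatter), a 1.1-fold higher number from compound 1 to compound 3 (0.02 log units; within the scatter) and a 1.3-fold higher number from compound 2 to compound 3 (0.12 log units; within the scatter). All three stay within the scatter, but none tests a non-aromatic ring there, so no step beyond the scatter is expected, though with some uncertainty. The expected step is a 1.2-fold higher number from compound 3 to compound 4 (0.07 log units; within the scatter). For compound 4, the estimate is 4 nM, with an expected range from 1.5 nM to 12 nM.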

Compound 4, half-maximal inhibitory concentration: 20000 nM
For compound 4 the middle estimate is 5000-fold (3.70 log units) below the measured one; measured number above the stated range.
By their numbers in this assay, from the lowest: compounds 2, 1 and 3 (each within the scatter of the next); then compound 4.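

In this assay this aromatic carbon, ortho to a cyano group, proves sensitive to what it carries: piperazin-1-yl gives a 5900-fold higher number from compound 3 to compound 4 (3.77 log units; beyond the scatter) and a 7800-fold higher number from compound 2 to compound 4 (3.89 log units; beyond the scatter) and a 6300-fold higher number from compound 1 to compound 4 (3.80 log units; beyond the scatter) in large steps. Going by these compounds alone, the earlier groups, all ring-free or aromatic, had stayed within the scatter of one another, so the first step beyond the scatter at this position comes with the non-aromatic ring. No measurement shown here accounts for this loss. On these data alone, it remains open whether the ring itself or its second nitrogen carries the change. Morpholin-4-yl, piperidin-1-yl or 4-methylpiperazin-1-yl at this carbon could separate the two.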